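Dropping one chloro from a dichloropurine: what to expect

The source may report more compounds than this note shows. Statements on the series, on what has been measured and on what is new or still open speak of the compounds shown alone.

Measured so far:
compound 1 `ClCc1cccc(Cn2cnc3c(Cl)nc(Cl)nc32)c1` gives 1730 nM
compound 2 `ClCc1ccccc1Cn1cnc2nc(Cl)nc(Cl)c21` gives 19500 nM
compound 3 `ClCc1ccc(Cn2cnc3c(Cl)nc(Cl)nc32)cc1` gives 6610 nM

All three values come from a functional assay on TK-10 cells (Homo sapiens) for cytotoxicity, read by sulforhodamine B assay, with a stated time of 48 h; a lower number here means a stronger inhibitor of growth, a higher number a weaker inhibitor of growth. The compounds share the same core and differ only in how the chloromethyl-bearing benzyl portion is arranged. On these numbers compound 2 stands highest, meaning the weakest growth inhibition of the three; compound 3 is the nearest to it and compound 1 the furthest, and both gaps lie beyond the usual scatter.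

Compound 4 `ClCc1ccccc1Cn1cnc2ncnc(Cl)c21` has not yet been measured. It differs from compound 2 in one place: hydrogen in place of chloro on an aromatic carbon. Among the compounds with values here, nothing among the measured compounds shows what this change does, since every measured compound carries both chloro groups on the core. Within the data shown here, with no step of this kind on record, the expectation for this assay is a small step, if any, from compound 2 to compound 4, and its direction is open; a modest weakening is taken as the slightly more likely outcome, since compound 2 already gives 19500 nM and the change removes a group rather than adding one. The expected step is a 1.3-fold higher number from compound 2 to compound 4 (0.11 log units; within the scatter). Compound 4 is therefore estimated at 25000 nM, with a range from 8000 nM to 80000 nM.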

Compound 4, concentration for 50% growth inhibition: 3460 nM
Compound 4: middle estimate off by 7.2-fold (0.86 log units), on the high side, outside the stated range (below it).
By their numbers in this assay, from the lowest: compounds 1, 4 and 3 (each within the scatter of the next, the first and the last beyond it); then compound 2.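

Replacing the chloro on the aromatic carbon between two ring nitrogen atoms with hydrogen gives a 5.6-fold lower number from compound 2 to compound 4 (0.75 log units; beyond the scatter) in this assay, so for this pair the loss of that chloro goes with stronger growth inhibition, not weaker. Within the data shown here, compounds 1, 2 and 3 all carry both chloro groups on the core, so only this pair isolates the position, and it shows that this chloro is not required for activity in compound 2 and that the position can change the read-out by more than the usual scatter. No measurement shown here explains why the number falls with this change.

A single pair cannot show whether hydrogen is the best choice at this position, and an amine, a methoxy group or a methyl group in the same place would test whether other replacements also give a lower number than the chloro of compound 2. From the compounds shown here alone, it also remains open whether the same change would produce a similar step with the arrangements of the chloromethyl-bearing benzyl portion found in compound 1 and compound 3.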